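The compounds below may be only part of what the source reports. "The series", "measured", "known", "first", "only" and "open" are said of these compounds alone.

Measured compounds:
compound 1 `CC(C)[C@H](NC(=O)CN(c1nc(Cl)nc2[nH]cnc12)C1CC1)C(=O)OCc1ccccc1` — 27.3%
compound 2 `C[C@@H](O)[C@H](NC(=O)CN(c1nc(Cl)nc2[nH]cnc12)C1CC1)C(=O)OCc1ccccc1` — 30.7%
compound 3 `O=C(CN(c1nc(Cl)nc2[nH]cnc12)C1CC1)N[C@@H](CCC(=O)OCc1ccccc1)C(=O)OCc1ccccc1` — 45.9%

In a functional assay on the whole organism (Tail, strain ICR) with Mus musculus as the target, in the tail flick test, with a stated time of 120 min, at a dose of 25 umol/kg by the oral route (on this read-out lower numbers stand for a weaker effect and higher numbers for a stronger effect at the one dose given), compound 2 stands second highest of the three numbers. Against compound 1 the step is a number 3.4 percentage points higher from compound 1 to compound 2 (within the scatter), whereas a number 15.2 percentage points higher from compound 2 to compound 3 (beyond the scatter) lies beyond the scatter, as does a number 18.6 percentage points higher from compound 1 to compound 3 (beyond the scatter). Compound 4 `C[C@@H](O)[C@H](NC(=O)CN(c1nc(Cl)nc2[nH]cnc12)C1CC1)C(=O)O` arises from compound 2 by hydrogen in place of benzyl on an oxygen next to a carbonyl group. Within the data shown here, all three measured steps alter the group on the saturated chain carbon bound to the amide-type nitrogen and the carbonyl carbon; none touches the oxygen next to the carbonyl group, so no measured step bears on the present change. The expectation for compound 4 therefore rests on compound 2 alone and carries a wide range; in this assay a step of a number 8.7 percentage points lower from compound 2 to compound 4 (within the scatter) is expected. Compound 4 is estimated at 22%, between 6% and 42%.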

Compound 4, a percentage reported as activity, at one dose (the size of the read-out at that dose, not a potency): 37.6%
Beside the measured number, compound 4's estimate is 15.6 percentage points below it, and the stated range covers the measured number.
By their numbers in this assay, from the lowest: compounds 1, 2, 4 and 3 (each within the scatter of the next, the first and the last beyond it).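

In this assay, hydrogen in place of benzyl on an oxygen next to a carbonyl group gives a number 6.9 percentage points higher from compound 2 to compound 4 (within the scatter), the only step shown at this oxygen. On this one pair, carboxy in place of benzyloxycarbonyl leaves compound 4 within the scatter of compound 2, so the benzyl group is not needed for the effect at the one dose given. No measured evidence bears on this result.

From the compounds shown here alone, whether the same change holds on the side chains of compound 1 and compound 3 remains open. Also open, going by these compounds, is what methyl or ethyl in place of benzyl on this oxygen would give.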